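This account rests on a few compounds, and the source may have more. Where it says the series, first, only, none or still open, it means among the compounds named here.

Of the compounds shown here, three sharing one core have been measured in a functional assay on DU-145 cells (Homo sapiens) for inhibition; on this read-out higher numbers stand for weaker inhibition and lower numbers for stronger inhibition. Compound 1 `Oc1cccc(-c2cc(-c3cccc(F)c3)cc(-c3cccc(O)c3)n2)c1` gives 23800 nM. Compound 2 `Oc1cccc(-c2cc(-c3ccc(F)cc3)cc(-c3cccc(O)c3)n2)c1` gives 7120 nM, and compound 3 `Oc1cccc(-c2cc(-c3ccccc3C(F)(F)F)cc(-c3cccc(O)c3)n2)c1` gives 2870 nM. Of the three numbers, compound 1 carries the highest, so on this read-out it is the weakest inhibitor of the set. The steps away from it are a 3.3-fold lower number from compound 1 to compound 2 (0.52 log units; beyond the scatter) and an 8.3-fold lower number from compound 1 to compound 3 (0.92 log units; beyond the scatter); between the two others the step is a 2.5-fold lower number from compound 2 to compound 3 (0.39 log units; beyond the scatter).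

Compound 4 `Oc1cccc(-c2cc(-c3cccc(OC(F)(F)F)c3)cc(-c3cccc(O)c3)n2)c1` has not yet been measured. It differs from compound 1 in one place: trifluoromethoxy in place of fluoro on an aromatic carbon. Going by the values given here, no measured step swaps the fluoro of compound 1 for a trifluoromethoxy group, so none bears on it directly. What the measured steps do show is that each change made on that ring of compound 1 gave a lower number, the smaller of the two being a 3.3-fold lower number from compound 1 to compound 2 (0.52 log units; beyond the scatter). A modest move in the same direction is therefore expected, not larger than those steps, with the possibility of no change beyond the scatter kept open. The expected step is a 3.0-fold lower number from compound 1 to compound 4 (0.47 log units; beyond the scatter). Compound 4 is estimated at 8000 nM, with a range from 2500 nM to 25000 nM.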

Compound 4, half-maximal inhibitory concentration: > 50000 nM
Compound 4: only a limit was reported (the forecaster's own chance of this, stated with the estimate: 5%); middle value at least 6.2-fold (0.79 log units) away from the limit.
By their numbers in this assay, from the lowest: compound 3; then compound 2; then compound 1. At a limit, above all of these: compound 4.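

Going by these compounds alone, this change runs the opposite way to the earlier steps on this ring, all of which lowered the number: in this assay, trifluoromethoxy in place of fluoro gives an at least 2.1-fold higher number from compound 1 to compound 4 (0.32 log units; beyond the scatter). Compound 4 stands at a limit of the assay and not at a true number, which fixes the direction of the step but not its full size: the limit of > 50000 nM in this assay, at which 1 of the 4 values shown sits. On an aromatic carbon meta to a large group, then, swapping fluoro with its 1 heavy atom for trifluoromethoxy with its 5 heavy atoms and 1 hydrogen-bond acceptor goes with weaker inhibition, so changes on this ring do not all strengthen it, though this single pair cannot tell which feature of the new group matters.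

The compounds shown leave open whether a methoxy group, a chlorine atom or an amine at this same carbon would also weaken inhibition, or whether the result is particular to trifluoromethoxy. Also open, going by these compounds, is how trifluoromethoxy would behave on the ring carbon that carries the fluoro in compound 2.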